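This account rests on a few compounds, and the source may have more. Where it says the series, first, only, none or still open, it means among the compounds named here.

Compound 1 `O=C(O)CCc1ccc(C#Cc2ccnc(Cl)n2)cc1` is the starting point of this account. In an in vitro functional assay on 1321-N1 cells for agonist activity at Free fatty acid receptor 1 (Homo sapiens), read by fluorescence, spectrophotometry and calcium flux (a lower number here means that less compound is needed, a higher number that more compound is needed for the effect), compound 1 gives 9120 nM. Among the three measured compounds it sits alongside compound 3 `COc1nccc(C#Cc2ccc(CCC(=O)O)cc2)n1`, which in this assay gives 9550 nM, a number indistinguishable from that of compound 1 within the usual scatter. Compound 2 `O=C(O)C1CC1c1ccc(C#Cc2cc(Cl)nc(Cl)c2)cc1` gives 42.7 nM in this assay, a far lower number, well beyond the scatter. The unmeasured compound 4 `Cc1cc(C#Cc2ccc(CCC(=O)O)cc2)nc(Cl)n1` differs from compound 1 in one place: methyl in place of hydrogen on an aromatic carbon. Among the compounds with values here, only one measured step involves this core, a 1.0-fold higher number from compound 1 to compound 3 (0.02 log units; within the scatter), and it concerns a different change, so no step speaks directly to a methyl entering here. The expectation is therefore a step of a 1.0-fold lower number from compound 1 to compound 4 (0.01 log units; within the scatter) that stays within the scatter. For compound 4 an estimate of 9000 nM, in a range from 3500 nM to 23000 nM, is expected.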

Compound 4, half-maximal effective concentration: 2750 nM
The estimate for compound 4 lay 3.3-fold (0.51 log units) above the measured number; measured number outside the range, below it.
By their numbers in this assay, from the lowest: compound 2; then compound 4; then compounds 1 and 3 (each within the scatter of the next).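

In this assay, a methyl on the aromatic carbon next to the ring nitrogen gives a 3.3-fold lower number from compound 1 to compound 4 (0.52 log units; beyond the scatter). Within the data shown here, this shows that the position responds to a single added carbon, although the step is modest, whereas the only earlier step on this core, a 1.0-fold higher number from compound 1 to compound 3 (0.02 log units; within the scatter), stayed within the scatter and concerned a different place. No available evidence accounts for this step. From the compounds shown here alone, whether an ethyl group or an amine on this same carbon would lower the number further remains open. So does whether the methyl step would hold with methoxy in place of chloro.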